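A Methyl Added to the Acyl Arm of Compound 3

This account rests on a few compounds, and the source may have more. Where it says the series, first, only, none or still open, it means among the compounds named here.

Compound 1, `CCC(=O)N1CCN(C(=O)c2ccccc2)C1`, gives 1 mg/kg in a functional assay on the whole organism with Mus musculus as the target; a lower number here means that less compound is needed, a higher number that more compound is needed for the effect.
Compound 2, `CCCS(=O)(=O)N1CCN(C(=O)CC)C1`, gives > 10 mg/kg in this assay, which is a limit of the assay and not a number.
Compound 3, `CC(=O)N1CCCN(S(=O)(=O)c2ccc(F)cc2)C1`, gives 1 mg/kg in this assay.

Compound 3 stands level with compound 1 at the digits shown, within the scatter; the only other value shown is the limit, (the limit of > 10 mg/kg in this assay, at which 1 of the 3 values shown sits), which belongs to compound 2. Compound 4, `CCC(=O)N1CCCN(S(=O)(=O)c2ccc(F)cc2)C1`, differs from compound 3 by methyl in place of hydrogen on a saturated chain carbon bound to a carbonyl carbon. Among the measured compounds shown here, no measured pair is separated by this change alone. The step from compound 3 to compound 4 is expected to be none beyond the scatter in this assay, since compound 1 carries the same propanoyl group and gives 1 mg/kg. Compound 4 is therefore estimated at 1 mg/kg, with a range from 0.3 mg/kg to 3 mg/kg, an expected step of no change at the digits printed from compound 3 to compound 4 (within the scatter).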

Compound 4, minimum effective dose: 1 mg/kg
For compound 4 middle estimate and measured number coincide at the digits printed; the measured number falls inside the stated range.
By their numbers in this assay, from the lowest: compounds 1, 3 and 4 (each within the scatter of the next). At a limit, above all of these: compound 2.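

In this assay, replacing acetyl with propanoyl gives no change at the digits printed from compound 3 to compound 4 (within the scatter). Among the compounds shown here, this is the first step that can be read at this place, a saturated chain carbon bound to a carbonyl carbon, since the earlier compounds carried acetyl or propanoyl only on differing structures and could not isolate the change. No measurement shown offers a cause for this result.

As far as these compounds go, how a longer chain, such as butanoyl, or an amine on this acyl arm would read remains open. So does whether the same methyl step would hold on the core of compound 1.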